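Three limits and a trifluorophenyl exchange

The source may report more compounds than this note shows. Statements on the series, on what has been measured and on what is new or still open speak of the compounds shown alone.

Compound 3 `Cc1cc(NCc2ccccn2)n2ncc(-c3ccc(F)cc3F)c2n1` is known only by a limit in a physicochemical assay for solubility, read by HPLC, using the shake flask method, measured as kinetic solubility, with a stated time of 2 h, at pH 7.4; a higher number here means a more soluble compound, a lower number a less soluble compound: compound 3 gives < 5000 nM. Compound 1 `Cc1cc(NCc2ccccn2)n2ncc(-c3ccc(N(C)C)cc3)c2n1` likewise gives only a limit, < 5000 nM. Compound 2 `Cc1cc(NCc2ccccn2)n2ncc(-c3c(C)cccc3C)c2n1` also gives only a limit, < 5000 nM. All three values therefore sit at the limit of < 5000 nM in this assay, at which 3 of the 3 values shown sit, and the steps among them cannot be read: a step that the two limits leave unreadable from compound 1 to compound 2, a step that the two limits leave unreadable from compound 1 to compound 3 and a step that the two limits leave unreadable from compound 2 to compound 3. Compound 4 `Cc1cc(NCc2ccccn2)n2ncc(-c3cc(F)c(F)c(F)c3)c2n1` has not yet been measured; it differs from compound 3 by 3,4,5-trifluorophenyl in place of 2,4-difluorophenyl on an aromatic carbon. Among the measured compounds shown here, none of the measured steps has a readable size, so the change cannot be sized from them, and the only guidance is that every measured compound sharing this core stays at the limit. Compound 4 is therefore expected to give about 2000 nM, with a range from 200 nM to 8000 nM, and most probably to be reported again as a limit. The estimated step is a step that the limit leaves unreadable from compound 3 to compound 4, which is expected to lie within the scatter.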

Compound 4, solubility: < 5000 nM
Compound 4 ended at the assay's limit (the forecaster's own chance of this, stated with the estimate: 75%); the middle value is on the limit's open side.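

Compound 4 gives only a limit, so its steps from compound 1, compound 2 and compound 3 cannot be read in this assay: the limit of < 5000 nM in this assay, at which 4 of the 4 values shown sit.

The compounds shown leave open whether exchanging the aryl group on the shared core changes solubility at all, and by how much.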